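Fluoro for Chloro on the Aryl Ring of Compound 1

The compounds below may be only part of what the source reports. "The series", "measured", "known", "first", "only" and "open" are said of these compounds alone.

Among the compounds with values here, compound 1 `O=S(=O)(c1cc(Cl)cc(Cl)c1)c1cnc2cc(F)ccc2c1-c1ccc(Cl)cc1` gives 30 mg/kg in a functional assay on the whole organism (strain Wistar) with Rattus norvegicus as the target (on this read-out lower numbers stand for an effect already at smaller amounts and higher numbers for an effect only at larger amounts of compound), the highest of the two numbers measured so far, while compound 2 `O=S(=O)(c1ccc(F)c(F)c1)c1cnc2cc(F)ccc2c1-c1ccc(Cl)cc1` gives 10 mg/kg. Within the data shown here, the only measured step, a 3.0-fold lower number from compound 1 to compound 2 (0.48 log units; beyond the scatter), concerns the group on the sulfonyl sulfur and not the ring altered here. Among the measured compounds shown here, compound 3 `O=S(=O)(c1cc(Cl)cc(Cl)c1)c1cnc2cc(F)ccc2c1-c1ccc(F)cc1` differs from compound 1 by fluoro in place of chloro on an aromatic carbon, a change for which no measured pair exists. With nothing to argue for a shift, the step of no change at the digits printed from compound 1 to compound 3 (within the scatter) is expected to stay within the scatter. Compound 3 is therefore estimated at 30 mg/kg, ranging from 10 mg/kg to 100 mg/kg.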

Compound 3, minimum effective dose: > 30 mg/kg
Compound 3 ended at the assay's limit (the forecaster's own chance of this, stated with the estimate: 10%); the middle value sits exactly at the limit.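

In this assay compound 3 gives > 30 mg/kg, which is a limit of the assay and not a number. Fluoro in place of chloro gives a number no lower from compound 1 to compound 3 (the limit leaves the size open), so 4-fluorophenyl brought no measurable gain here, whereas changing the group on the sulfonyl sulfur gave a 3.0-fold lower number from compound 1 to compound 2 (0.48 log units; beyond the scatter). The size of the step from 4-chlorophenyl to 4-fluorophenyl cannot be read: the limit of > 30 mg/kg in this assay, at which 1 of the 3 values shown sits.

On these data alone, it remains open whether a methoxy group or an amine in place of the chloro would lower the number. Also open, as far as these compounds go, is how 4-fluorophenyl would behave alongside the sulfonyl group of compound 2.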